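A few compounds are considered here, and "the series" means these few. Any claim that something is new, unique, unknown or untested is made for them only; others in the source may bear on it.

Three close relatives built on one shared core have been tested in an assay for inhibition of Alpha amylase (Homo sapiens), with a stated time of 10 min; a higher number here means a weaker inhibitor, a lower number a stronger inhibitor. Compound 1 `COc1ccc(/C=C2/C(=O)N(c3ccc(Cl)cc3)N=C2C)c(OC)c1` gives 2010 nM. Compound 2 `COc1ccc(OC)c(/C=C2/C(=O)N(c3ccc(Cl)cc3)N=C2C)c1` gives 2130 nM in this assay, and compound 3 `COc1ccc(/C=C2/C(=O)N(c3ccc(Cl)cc3)N=C2C)cc1OC` gives 2030 nM. On these numbers compound 3 stands second highest of the three, but its nearest neighbour, compound 1, and its furthest neighbour, compound 2, both sit within the usual scatter of it, so the three cannot be told apart by this readout. Going by the values given here, the only thing that changes among them is where two methoxy groups sit on the same aromatic ring, and that shuffling has not moved the numbers.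

Compound 4 `COc1cc(/C=C2/C(=O)N(c3ccc(Cl)cc3)N=C2C)cc(OC)c1OC` has not yet been measured. It differs from compound 3 by methoxy in place of hydrogen on an aromatic carbon, so it carries three methoxy groups on that ring instead of two. Among the compounds with values here, no pair of measured compounds differs in exactly this way, so the step has to be guessed from the flat picture above. Since compound 1 gives 2010 nM and compound 2 gives 2130 nM while compound 3 gives 2030 nM, the expected step is a 1.0-fold higher number from compound 3 to compound 4 (0.01 log units; within the scatter), nothing beyond the scatter in either direction. Compound 4 is accordingly estimated at 2100 nM, with a range from 900 nM to 5000 nM.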

Compound 4, half-maximal inhibitory concentration: 2190 nM
Compound 4: middle estimate off by 1.0-fold (0.02 log units), on the low side; measured number inside the range.
By their numbers in this assay, from the lowest: compounds 1, 3, 2 and 4 (each within the scatter of the next).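

In this assay the added methoxy group gives a 1.1-fold higher number from compound 3 to compound 4 (0.03 log units; within the scatter) and so leaves the reading within ordinary measurement noise. Going by these compounds alone, the earlier compounds showed only that two methoxy groups can stand in different places on this ring with no readable difference, whereas this pair shows that going from two to three methoxy groups also brings none, at this position that is ortho to a methoxy group and meta to a large group. That finding rests on a single pair, and nothing measured here explains why the extra group leaves the number unmoved.

From the compounds shown here alone, every substituent varied so far is a methoxy group on this one ring, so it remains open whether a different group at this position, such as a hydroxyl, an amine, a carboxylic acid or a longer chain like butoxy, would shift the number beyond the scatter. Also open, going by these compounds, is how much the rest of the shared core contributes, including the chlorine and the methyl group, as both stay the same across all four compounds.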